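The source may report more compounds than this note shows. Statements on the series, on what has been measured and on what is new or still open speak of the compounds shown alone.

Among the three compounds measured so far, compound 2 (`CCCCCCCC/C=C\CCCCCCC(=O)c1ncc(-c2ccncc2)o1`) is the only one with a definite number: in an assay on isolated protein for inhibition of Fatty-acid amide hydrolase 1 (Homo sapiens) (a lower number here means a stronger inhibitor, a higher number a weaker inhibitor), compound 2 gives 56 nM. Compound 1 (`CCCCCCCC/C=C\CCCCCCCC(OC)OC`) gives only a limit, > 300000 nM, which is the limit of > 300000 nM in this assay, at which 1 of the 3 values shown sits. Compound 3 (`O=C(CCCCCCc1ccccc1)c1nnn[nH]1`) likewise gives only a limit, > 1000 nM, which is the limit of > 1000 nM in this assay, at which 1 of the 3 values shown sits. Within the data shown here, no two measured compounds differ in just one place, so nothing shows how a single change shifts the inhibition constant here. Compound 4 (`CCCCCCCC/C=C\CCCCCCC(=O)c1ncc(-c2ccoc2)o1`) has not been measured; it differs from compound 2 by furan-3-yl in place of pyridin-4-yl on an aromatic carbon. The step from compound 2 to compound 4 is expected to be small, close to the scatter, and if anything toward weaker inhibition, a 2.3-fold higher number from compound 2 to compound 4 (0.37 log units; beyond the scatter). Compound 4 is therefore estimated at 130 nM, with a range of 40 nM to 450 nM.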

Compound 4, inhibition constant: 610 nM
Compound 4: middle estimate off by 4.7-fold (0.67 log units), on the low side; measured number above the stated range.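

Among these compounds, putting furan-3-yl in place of pyridin-4-yl on the aromatic carbon next to the ring oxygen gives an 11-fold higher number from compound 2 to compound 4 (1.04 log units; beyond the scatter) in this assay, the first step here that isolates one change. This position is therefore sensitive to which ring it carries, even though both groups are aromatic rings with 1 hetero atom and no net charge. No measurement shown here explains the step.

On these data alone, it remains open whether ring size or the kind and place of the hetero atom matters more. A phenyl or pyridin-3-yl group at this position would help separate these possibilities.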